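Trifluoromethyl for methyl at the terminal phenyl ring

The source may hold more compounds than are shown below. What is called first, only, known or untested is meant among the compounds shown, and "the series" means these compounds.

Among the compounds with values here, compound 2 `COc1cc2cc(Oc3ccc(NC(=O)Nc4ccc(C)cc4)cc3)c(C)nc2cc1OC` stands highest of the two numbers so far in a functional assay on OVCAR-3 cells (Homo sapiens) for inhibition, read by sulforhodamine B assay, with a stated time of 48 h, tested at 10 uM (on this read-out higher numbers stand for a weaker effect at the one concentration tested and lower numbers for a stronger effect), where compound 2 gives 113%. Within the data shown here, its only neighbour is compound 1 `COc1cc2cc(Oc3ccc(NC(=O)Nc4ccccc4)cc3)c(C)nc2cc1OC`, which in this assay gives 67.1%. Among the measured compounds shown here, the one measured step, a number 45.9 percentage points higher from compound 1 to compound 2 (beyond the scatter), is beyond the scatter and runs toward the weaker end of the read-out.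

Compound 3 `COc1cc2cc(Oc3ccc(NC(=O)Nc4ccc(C(F)(F)F)cc4)cc3)c(C)nc2cc1OC` differs from compound 2 by trifluoromethyl in place of methyl on an aromatic carbon. For the measured compounds named here, no measured step covers this exchange: the only step on record concerns methyl in place of hydrogen at the same aromatic carbon, not trifluoromethyl in place of methyl, so it bears on compound 3 only indirectly, in that the two compounds so far carrying a substituent or none at that carbon differ by a large amount. Going by the values given here, with that single large step as the only guide, the size and direction of a number 18 percentage points lower from compound 2 to compound 3 (beyond the scatter) is expected to be uncertain, and a step not clearly beyond the scatter is the plainest expectation. Compound 3 is therefore estimated at 95% in this assay, within a range from 60% to 120%.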

Compound 3, a percentage reported as activity, at one concentration (the size of the read-out at that concentration, not a potency): 67%
Compound 3: the middle estimate sits 28 percentage points above what was measured; the measured number falls inside the stated range.
By their numbers in this assay, from the lowest: compounds 3 and 1 (each within the scatter of the next); then compound 2.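

In this assay, going from the 4-methylphenyl to the 4-(trifluoromethyl)phenyl, a change on an aromatic carbon para to a large group, gives a number 46 percentage points lower from compound 2 to compound 3 (beyond the scatter), so the read-out here depends on which group is present, not only on whether the carbon carries a substituent. Trifluoromethyl in place of hydrogen at the same carbon gives a number 0.1 percentage points lower from compound 1 to compound 3 (within the scatter), which means that a substituent at this carbon does not in itself shift the number toward the weaker end, and among the three compounds only the methyl of compound 2 does so. Nothing in the material at hand explains why these two groups part so widely.

From the compounds shown here alone, what remains open is whether the large number belongs to methyl alone or is shared by other groups at this carbon, such as an ethyl or a longer chain, a methoxy group or an amine. Going by these compounds, it is equally open whether a single fluorine or chlorine atom, or a nitrile, would fall with compound 1 and compound 3 or with compound 2.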